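A few compounds are considered here, and "the series" means these few. Any claim that something is new, unique, unknown or untested is made for them only; others in the source may bear on it.

Measured compounds:
Compound 1: `COc1ccc(-c2cc(/C=C/C(=O)c3ccc(N)cc3)[nH]n2)cc1`, 44300 nM
Compound 2: `COc1cc(-c2cc(/C=C/C(=O)c3ccc(N)cc3)[nH]n2)cc(OC)c1OC`, 34000 nM

In a functional assay on SNB-19 cells (Homo sapiens) for inhibition, read by sulforhodamine B assay, with a stated time of 48 h (a higher number here means that more compound is tolerated, a lower number that less compound is tolerated), compound 1 gives 44300 nM, and in the same test compound 2 gives 34000 nM. Compound 2 stands next to compound 1: the gap between their two numbers lies within the usual scatter of repeated measurements, so neither compound can be separated from the other on these two values alone.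

Compound 3, `COc1ccc(-c2cc(/C=C/C(=O)c3ccc(N)cc3)[nH]n2)cc1OC`, is obtained from compound 2 by the change (hydrogen in place of methoxy on an aromatic carbon), that is, hydrogen in place of methoxy on an aromatic carbon. Compound 3 thus sits structurally between compound 1 and compound 2, which are themselves indistinguishable in this assay. Among the compounds with values here, no measured step of this kind exists here, so the expected size of the step is small: a change within the scatter, in no firm direction.

Compound 3 is therefore expected to give about 38000 nM in this assay, with a plausible range from 18000 nM to 80000 nM, a step of a 1.1-fold higher number from compound 2 to compound 3 (0.05 log units; within the scatter) that is estimated to stay within the scatter.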

Compound 3, concentration lethal to 50% of the cells: 46100 nM
Beside the measured number, compound 3's estimate is 1.2-fold (0.08 log units) below it, and the stated range covers the measured number.
By their numbers in this assay, from the lowest: compounds 2, 1 and 3 (each within the scatter of the next).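

In this assay, hydrogen in place of methoxy at this spot gives a 1.4-fold higher number from compound 2 to compound 3 (0.13 log units; within the scatter), while methoxy in place of hydrogen at the same spot gives a 1.0-fold higher number from compound 1 to compound 3 (0.02 log units; within the scatter), so the two steps approach one position from opposite sides. With a methoxy group on the ring, a second and a third methoxy group leave the number within the scatter in this set, and the two earlier compounds alone could not show this for a single methoxy step at this place. Nothing measured here offers an explanation for this flat result.

The compounds shown leave open whether a group other than methoxy at this place, such as a hydroxyl, an amine or a longer chain like ethoxy, would move the number beyond the scatter. They also leave open whether a ring with no methoxy group at all would read the same.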